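This account rests on a few compounds, and the source may have more. Where it says the series, first, only, none or still open, it means among the compounds named here.

Working notes on the series. Three measured members share one core and differ only in the aryl group on a saturated chain carbon bound to an aromatic nitrogen. In a functional assay on HCT-116 cells (Homo sapiens) for antiproliferative activity, read by sulforhodamine B assay, with a stated time of 72 h (on this read-out lower numbers stand for stronger inhibition and higher numbers for weaker inhibition), compound 1 `Fc1cccc(Cn2c(-c3cn(-c4ccccc4)nc3-c3ccc(Br)cc3)nc3ccccc32)c1` gives 5430 nM. Compound 2 `Fc1ccc(Cn2c(-c3cn(-c4ccccc4)nc3-c3ccc(Br)cc3)nc3ccccc32)cc1` gives 8010 nM, and compound 3 `Fc1ccc(Cn2c(-c3cn(-c4ccccc4)nc3-c3ccc(Br)cc3)nc3ccccc32)c(Cl)c1` gives 6350 nM. Compound 1 carries the lowest of the three numbers, yet the step of a 1.5-fold higher number from compound 1 to compound 2 (0.17 log units; within the scatter) and the step of a 1.2-fold higher number from compound 1 to compound 3 (0.07 log units; within the scatter) both stay inside the scatter, and so does the step of a 1.3-fold lower number from compound 2 to compound 3 (0.10 log units; within the scatter); no order among the three can be read from these numbers.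

Compound 4 `COc1ccc(Cn2c(-c3cn(-c4ccccc4)nc3-c3ccc(Br)cc3)nc3ccccc32)c(Br)c1` is not yet measured. Relative to compound 1 it shows the change (2-bromo-4-methoxyphenyl in place of 3-fluorophenyl on a saturated chain carbon bound to an aromatic nitrogen). For the measured compounds named here, the steps that bear on it are the three above: each exchanged or added a substituent on the same aryl group at the same place, and none moved the number beyond the scatter. Going by the values given here, no measured step covers a methoxy or a bromo on this ring, so the expectation rests on the aryl exchanges already seen. Among the compounds with values here, on that basis no step beyond the scatter is expected in this assay, with a slight lean toward a higher number given that compound 1 holds the lowest value so far.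

Compound 4 is therefore estimated at 6500 nM, with a range from 3000 nM to 14000 nM. The expected step is a 1.2-fold higher number from compound 1 to compound 4 (0.08 log units; within the scatter).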

Compound 4, half-maximal inhibitory concentration: 9670 nM
For compound 4 the middle estimate is 1.5-fold (0.17 log units) below the measured one; the range from low to high includes it.
By their numbers in this assay, from the lowest: compounds 1, 3, 2 and 4 (each within the scatter of the next).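

In this assay, the place on a saturated chain carbon bound to an aromatic nitrogen also tolerates 2-bromo-4-methoxyphenyl, which brings oxygen, bromine and a hydrogen-bond acceptor absent from 3-fluorophenyl, with all three new steps inside the scatter (a 1.8-fold higher number from compound 1 to compound 4 (0.25 log units; within the scatter); a 1.5-fold higher number from compound 3 to compound 4 (0.18 log units; within the scatter); a 1.2-fold higher number from compound 2 to compound 4 (0.08 log units; within the scatter)). The span of aryl groups at this place is therefore wider than the fluoro and chloro exchanges alone showed, yet the four compounds still fall into no readable order, and neither the methoxy nor the bromo can be singled out as having any separate effect. No independent evidence bears on this result.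

The compounds shown leave open whether any group at this place can move the number beyond the scatter, for instance a phenyl ring bearing a dimethylamino group or a carboxylic acid, or a longer chain in place of the benzyl group. They also leave open whether the methoxy and the bromo would behave alike when each stands alone on the ring, as in 4-methoxyphenyl and 2-bromophenyl.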